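Amine replacement on the shared core: compound 1 to compound 4

The source may hold more compounds than are shown below. What is called first, only, known or untested is meant among the compounds shown, and "the series" means these compounds.

Working notes on the series. In a functional assay on MDA-MB-435 cells (Homo sapiens) for cytotoxicity, read by MTT assay, with a stated time of 72 h (a higher number here means a weaker inhibitor, a lower number a stronger inhibitor), compound 1 `Nc1cccc(Nc2c(C(=O)NCc3ccc(F)cc3)nc(Br)c3cccnc23)c1` gives 8000 nM, the highest number among the three measured compounds, but the gap to either neighbour sits within the usual scatter. Compound 3 `COc1cccc(CNC(=O)c2nc(Br)c3cccnc3c2N[C@H]2CC[C@H](N)CC2)c1` gives 7000 nM in this assay, and compound 2 `N[C@H]1CC[C@H](Nc2c(C(=O)NCc3ccc(Oc4ccccc4)cc3)nc(Br)c3cccnc23)CC1` gives 4000 nM in this assay; neither separates from compound 1 beyond the scatter, so no order among the three can be read.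

Compound 4 `NCCNc1c(C(=O)NCc2ccc(F)cc2)nc(Br)c2cccnc12` is not yet measured. It differs from compound 1 in one place: 2-aminoethyl in place of 3-aminophenyl on a nitrogen on an aromatic ring. Going by the values given here, no measured step covers this change. The expectation is for a step within the scatter, if anything toward a slightly higher number, so that a 1.3-fold higher number from compound 1 to compound 4 (0.10 log units; within the scatter) is estimated. For compound 4 the estimate in this assay is 10000 nM, with a range from 4000 nM to 25000 nM.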

Compound 4, half-maximal inhibitory concentration: 12000 nM
The estimate for compound 4 lay 1.2-fold (0.08 log units) below the measured number; the range from low to high includes it.
By their numbers in this assay, from the lowest: compounds 2, 3, 1 and 4 (each within the scatter of the next, the first and the last beyond it).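

In this assay, the first step measured at this place is a 1.5-fold higher number from compound 1 to compound 4 (0.18 log units; within the scatter), with 2-aminoethyl in place of 3-aminophenyl on a nitrogen on an aromatic ring. At this level of cytotoxicity, compound 4 does not separate from compound 1, so swapping the six-membered aromatic ring of carbon for an open chain with no ring makes no readable difference. Nothing available gives a reason for this result.

Going by these compounds, whether a longer chain or a carboxylic acid in place of the amine would separate from compound 1 stays open. So does whether 2-aminoethyl gives a similar step with a different group on the amide.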